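Butyl in place of hydrogen on an N-aryl benzisothiazolone-type core

The source may report more compounds than this note shows. Statements on the series, on what has been measured and on what is new or still open speak of the compounds shown alone.

For the measured compounds named here, compound 1 `O=c1c2cccnc2sn1-c1ccccc1` gives 7850 nM in an assay for inhibition of histone acetyltransferase KAT2B (Homo sapiens), read by fluorescence (a lower number here means a stronger inhibitor, a higher number a weaker inhibitor), the lowest of the three numbers so far. Going by the values given here, compound 3 `O=c1c2cccnc2sn1Cc1ccccc1` gives 23000 nM, and compound 2 `Cc1ccc(Cn2sc3ncccc3c2=O)cc1` gives 27900 nM; the only measured single-site step, a 1.2-fold lower number from compound 2 to compound 3 (0.08 log units; within the scatter), was within the scatter. Compound 4 `CCCCc1ccc(-n2sc3ncccc3c2=O)cc1` differs from compound 1 by butyl in place of hydrogen on an aromatic carbon, para to a large group. Among the compounds with values here, the one step that bears on this, the methyl-for-hydrogen comparison between compound 2 and compound 3, was small, but butyl is a longer chain than methyl and sits on a ring joined directly to the core rather than through a methylene. Compound 4 is therefore expected to give about 8000 nM, between 2500 nM and 25000 nM, a step of a 1.0-fold higher number from compound 1 to compound 4 (0.01 log units; within the scatter) that is expected to stay near the scatter.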

Compound 4, half-maximal inhibitory concentration: 15900 nM
The estimate for compound 4 lay 2.0-fold (0.30 log units) below the measured number, and the stated range covers the measured number.
By their numbers in this assay, from the lowest: compound 1; then compounds 4, 3 and 2 (each within the scatter of the next).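

On the ring of compound 1, butyl gives a 2.0-fold higher number from compound 1 to compound 4 (0.31 log units; beyond the scatter) in this assay and thus a modest weakening, the first single-site step shown to pass the scatter. This place, para to a large group, therefore takes a chain of this length with only a modest loss. No measured evidence accounts for the step. Open, on these data alone, is whether the loss grows with chain length, as a comparison of ethyl or a longer chain at this place would show. Also open, as far as these compounds go, is how an amine or a carboxylic acid would fare there.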